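The compounds below may be only part of what the source reports. "The series", "measured", "known", "first", "only" and "open" are said of these compounds alone.

Compound 1 `CCCCCCCCc1ccc(OCC(=O)Cn2cnnn2)cc1`: 22%
Compound 2 `CCCCCCCCc1ccc(OCC(=O)Cn2nnc(SC)n2)cc1`: < 5%, a limit of the assay
Compound 3 `CCCCCCCCc1ccc(OCC(=O)Cn2nnc(C(=O)O)n2)cc1`: 52%

In an ADME assay on S9 fraction from liver (Rattus norvegicus) for metabolic stability, read by LC-MS, using NADPH, with a stated time of 30 min (on this read-out lower numbers stand for a less stable compound and higher numbers for a more stable compound), compound 1 gives 22%, the lowest of the two plain numbers shown; the nearest is compound 3, reached by a number 30 percentage points higher from compound 1 to compound 3 (beyond the scatter). Compound 2 sits at a limit, (the limit of < 5% in this assay, at which 1 of the 3 values shown sits). Compound 4 `CCCCCCCCc1ccc(OCC(=O)Cn2nnnc2C(=O)OCC)cc1` has not been measured; it differs from compound 1 by ethoxycarbonyl in place of hydrogen on an aromatic carbon. Among the compounds with values here, two measured steps bear on this change, though both also replace 1H-tetrazol-1-yl with a 2H-tetrazol-2-yl group: a number 30 percentage points higher from compound 1 to compound 3 (beyond the scatter), and a number at least 17 percentage points lower from compound 1 to compound 2 (beyond the scatter). They point in opposite directions, and ethoxycarbonyl is neither carboxy nor methylsulfanyl, so only a small step is expected in this assay, within the scatter or a little lower. Compound 4 is therefore estimated at 18%, between 5% and 40%, which would mean an expected a number 4 percentage points lower from compound 1 to compound 4 (within the scatter).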

Compound 4, percent of the compound remaining: 33%
Compound 4: the middle estimate sits 15 percentage points below what was measured; the measured number falls inside the stated range.
By their numbers in this assay, from the lowest: compound 1; then compound 4; then compound 3. At a limit, below all of these: compound 2.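

On the aromatic carbon between two ring nitrogen atoms, ethoxycarbonyl in place of hydrogen gives a number 11 percentage points higher from compound 1 to compound 4 (beyond the scatter) in this assay. Unlike the steps to compound 2 and compound 3, this step keeps the ring's link to the chain unchanged, so it isolates the effect of adding a group at this carbon. Nothing measured here accounts for the rise. As far as these compounds go, whether a methyl group or a primary amide on this same carbon would give a similar rise remains open.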